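The compounds below may be only part of what the source reports. "The series", "measured", "known", "first", "only" and "open" are said of these compounds alone.

In a functional assay on U-251 cells (Homo sapiens) (on this read-out higher numbers stand for weaker inhibition of growth and lower numbers for stronger inhibition of growth), compound 1 `Oc1cc(-c2ccc(Cl)cc2)nc2ncccc12` gives 39800 nM, while compound 2 `COc1cccc(-c2cc(O)c3cc(C)cnc3n2)c1` gives 44.7 nM. Compound 2 therefore holds the lower of the two numbers, with a gap well beyond the usual scatter. These two structures differ in more than one place, however, so the gap cannot be pinned on any single group. Compound 3 `COc1cccc(-c2cc(O)c3cccnc3n2)c1` differs from compound 2 at one site only: hydrogen in place of methyl on an aromatic carbon. Within the data shown here, no measured pair shows the effect of this change alone, so any forecast is uncertain. Among the measured compounds shown here, since only one small group is lost, a moderate weakening from the 44.7 nM of compound 2 is expected, not a drop to the level of compound 1. The expected step is a 4.5-fold higher number from compound 2 to compound 3 (0.65 log units; beyond the scatter), a rise beyond the scatter. For compound 3, the estimated value is 200 nM, with an expected range of 35 nM to 1200 nM.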

Compound 3, concentration for 50% growth inhibition: 55 nM
Compound 3: the middle estimate sits 3.6-fold (0.56 log units) above what was measured; low and high end bracket the measured number.
By their numbers in this assay, from the lowest: compounds 2 and 3 (each within the scatter of the next); then compound 1.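

In this assay the change from methyl to hydrogen on this aromatic carbon, two atoms from the ring nitrogen, gives a 1.2-fold higher number from compound 2 to compound 3 (0.09 log units; within the scatter) and so leaves the two compounds indistinguishable on this read-out. The methyl is therefore not needed for the low numbers of these two compounds, and losing it alone does not lead to a number like that of compound 1 with 39800 nM in this assay. There is no independent evidence that explains why this carbon accepts the change.

Among the compounds shown, only methyl and hydrogen can be compared at this carbon, so a longer chain such as ethyl, or an amine or a carboxylic acid, could still give a different number. Among these compounds, the high number of compound 1 also stays unexplained, since no single-site step links it to the other two.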